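This account rests on a few compounds, and the source may have more. Where it says the series, first, only, none or still open, it means among the compounds named here.

Compounds measured so far in an ADME assay on microsomes from liver (Homo sapiens) for metabolic stability, read by LC-MS, tested at 1 mM; on this read-out lower numbers stand for a shorter-lived compound and higher numbers for a longer-lived compound:
- compound 1 `CS(=O)(=O)c1cccc(-c2c[nH]c3c(=O)n(Cc4cc(F)ccc4C#N)c(N4CCC[C@@H](N)C4)nc23)c1` — > 3.33 h
- compound 2 `CC(C)S(=O)(=O)c1ccc(-c2c[nH]c3c(=O)n(Cc4cc(F)ccc4C#N)c(N4CCC[C@@H](N)C4)nc23)cc1` — 0.722 h
- compound 3 `CS(=O)(=O)c1ccccc1-c1c[nH]c2c(=O)n(Cc3cc(F)ccc3C#N)c(N3CCC[C@@H](N)C3)nc12` — > 3.33 h

In this assay compound 1 reaches only a limit, not a number, and so does compound 3; they sit at the limit of > 3.33 h in this assay, at which 2 of the 3 values shown sit. Within the data shown here, compound 2 gives the single numbered value. Among the measured compounds shown here, the step of an at least 4.6-fold lower number from compound 1 to compound 2 (0.66 log units; beyond the scatter) is the one readable step, while a step that the two limits leave unreadable from compound 1 to compound 3. The step of an at least 4.6-fold higher number from compound 2 to compound 3 (0.66 log units; beyond the scatter) mirrors the first.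

Compound 4 `N#Cc1ccc(F)cc1Cn1c(N2CCC[C@@H](N)C2)nc2c(-c3ccc(F)cc3)c[nH]c2c1=O` differs from compound 1 in one place: 4-fluorophenyl in place of 3-(methylsulfonyl)phenyl on an aromatic carbon. For the measured compounds named here, none of the measured steps removes the sulfonyl-bearing ring altogether, so the bearing is indirect. Going by the values given here, the only readable change to this ring, an at least 4.6-fold lower number from compound 1 to compound 2 (0.66 log units; beyond the scatter), shows that altering the group here can lower the number well beyond the scatter, and the expectation for compound 4 is a lowering of that kind, estimated as an at least 2.2-fold lower number from compound 1 to compound 4 (0.34 log units; beyond the scatter). Compound 4 is therefore expected to give about 1.5 h, in a range from 0.5 h to 4 h.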

Compound 4, half-life: 3.01 h
For compound 4 the middle estimate is 2.0-fold (0.30 log units) below the measured one, within the range that was stated.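

In this assay fluoro in place of isopropylsulfonyl gives a 4.2-fold higher number from compound 2 to compound 4 (0.62 log units; beyond the scatter) and shows that, at this position, a ring carrying no sulfonyl group can still give a much higher number than compound 2 does. A sulfonyl group is therefore not required for the higher numbers seen here. The steps of an at least 1.1-fold lower number from compound 1 to compound 4 (0.04 log units; that floor lies within the scatter) and an at least 1.1-fold lower number from compound 3 to compound 4 (0.04 log units; that floor lies within the scatter) each start from a value that is only a limit, so their true size cannot be read: the limit of > 3.33 h in this assay, at which 2 of the 4 values shown sit.

From the compounds shown here alone, how far compound 1 and compound 3 actually lie from compound 4 stays open. Also open, going by these compounds, is whether a plain phenyl ring, or a ring bearing an amine, a carboxylic acid or a methoxy group, would keep the number of compound 4 at this position.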